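Piperidinylmethyl in place of dimethylaminomethyl on the chloro analogue

The source may hold more compounds than are shown below. What is called first, only, known or untested is meant among the compounds shown, and "the series" means these compounds.

Two compounds of the series have numbers in an ADME assay on MCF-10A cells (Homo sapiens) for cytotoxicity, read by sulforhodamine B assay, with a stated time of 48 h; a higher number here means a weaker inhibitor of growth, a lower number a stronger inhibitor of growth. Compound 1 `Cc1ccc2nc(/N=C3\C(=O)N(CN4CCCCC4)c4cccc(Br)c43)sc2c1` gives 18400 nM in this assay. Compound 2 `Cc1ccc2nc(/N=C3\C(=O)N(CN(C)C)c4cccc(Cl)c43)sc2c1` gives 7020 nM, the lower of the two numbers; compound 1 sits a step above it that lies beyond the scatter. Compound 3 `Cc1ccc2nc(/N=C3\C(=O)N(CN4CCCCC4)c4cccc(Cl)c43)sc2c1` is not yet measured; it carries piperidin-1-yl in place of dimethylamino on a saturated chain carbon bound to an amide-type nitrogen in a ring. Compound 1 also carries the piperidin-1-yl group and gives 18400 nM, so a move toward a higher number is expected for compound 3, a modest step of a 1.7-fold higher number from compound 2 to compound 3 (0.23 log units; within the scatter). Compound 3 is thus estimated at 12000 nM, within 5000 nM to 30000 nM.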

Compound 3, concentration for 50% growth inhibition: 30200 nM
The estimate for compound 3 lay 2.5-fold (0.40 log units) below the measured number; the whole stated range lies below it.
By their numbers in this assay, from the lowest: compound 2; then compounds 1 and 3 (each within the scatter of the next).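

In this assay, among the compounds shown here, piperidin-1-yl in place of dimethylamino on a saturated chain carbon bound to an amide-type nitrogen in a ring gives a 4.3-fold higher number from compound 2 to compound 3 (0.63 log units; beyond the scatter), the first single-place reading of the amine on this chain carbon. Chloro in place of bromo on an aromatic carbon gives a 1.6-fold higher number from compound 1 to compound 3 (0.22 log units; within the scatter), so with piperidin-1-yl present this halogen swap is not resolved. Nothing at hand bears on the cause of either step.

Open, on these data alone, is how morpholin-4-yl or pyrrolidin-1-yl would read on the same chain carbon. Also open, as far as these compounds go, is whether the halogen swap stays unresolved with dimethylamino present.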